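This account rests on a few compounds, and the source may have more. Where it says the series, first, only, none or still open, it means among the compounds named here.

Series notes. Compound 1 `COc1ccc2c(c1)OC(c1cc(OC)c(OC)c(OC)c1)C(CO)=C2` carries a hydroxymethyl group on a double-bonded ring carbon of the shared core. In a functional assay for inhibition of nuclear factor NF-kappa-B complex (Homo sapiens) (a lower number here means a stronger inhibitor, a higher number a weaker inhibitor), compound 1 reaches only the limit of > 50000 nM. Compound 2 `COc1ccc2c(c1)OC(c1cc(OC)c(OC)c(OC)c1)C(C(=O)N1CCCCC1)=C2` carries a (piperidin-1-yl)carbonyl group on that double-bonded ring carbon. In this assay compound 2 likewise reaches only the limit of > 50000 nM. Within the data shown here, compound 3 `CCCC(=O)C1=Cc2ccc(OC)cc2OC1c1cc(OC)c(OC)c(OC)c1` carries a propylcarbonyl group on the double-bonded ring carbon, and in this assay compound 3 gives 11700 nM, the only actual number in the set. The step of an at least 4.2-fold lower number from compound 1 to compound 3 (0.63 log units; beyond the scatter) and the step of an at least 4.2-fold lower number from compound 2 to compound 3 (0.63 log units; beyond the scatter) both accompany the arrival of the propylcarbonyl group, while the step that the two limits leave unreadable from compound 1 to compound 2 stays unreadable because of the limit of > 50000 nM in this assay, at which 2 of the 3 values shown sit.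

Compound 4 `COc1ccc2c(c1)OC(c1cc(OC)c(OC)c(OC)c1)C=C2` removes that group: hydrogen in place of propylcarbonyl on a double-bonded ring carbon. The two readable steps both end at compound 3, so taking the propylcarbonyl away is expected to run the other way, and the step of a 4.3-fold higher number from compound 3 to compound 4 (0.63 log units; beyond the scatter) is therefore expected to be upward and of at least modest size. Compound 4 is estimated at 50000 nM, within a range from 15000 nM to 150000 nM, and a limit rather than a number is considered quite likely.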

Compound 4, half-maximal inhibitory concentration: 17700 nM
Estimate against measurement, compound 4: 2.8-fold (0.45 log units) above; the measured number falls inside the stated range.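

Removing the propylcarbonyl group gives a 1.5-fold higher number from compound 3 to compound 4 (0.18 log units; within the scatter), so in this assay this group shows no readable gain over plain hydrogen on the double-bonded ring carbon, and a measurable number at this position does not depend on it. The contrast within the series now lies with the other two groups, as hydrogen in their place gives an at least 2.8-fold lower number from compound 1 to compound 4 (0.45 log units; beyond the scatter) and an at least 2.8-fold lower number from compound 2 to compound 4 (0.45 log units; beyond the scatter). Compound 1 and compound 2 each stand only at a limit, so these two steps are minimum sizes and the step between those two compounds cannot be read: the limit of > 50000 nM in this assay, at which 2 of the 4 values shown sit.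

The compounds shown do not tell whether a longer chain on the carbonyl, an amine or a carboxylic acid on this ring carbon would move the number beyond the scatter from compound 4, in either direction. Every compound shown keeps the rest of the shared core unchanged, so how much of the activity of compound 3 and compound 4 comes from that core stays open.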